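Nitro for hydrogen on the sulfonyl-bearing ring

A few compounds are considered here, and "the series" means these few. Any claim that something is new, unique, unknown or untested is made for them only; others in the source may bear on it.

Compound 1 `CC1CCc2ccccc2N1S(=O)(=O)c1ccccc1` gives 70000 nM in an ADME assay on L6 cells (Rattus norvegicus) for cytotoxicity (a lower number here means a stronger inhibitor, a higher number a weaker inhibitor), the highest of the two numbers measured. Compound 2 `CC1CCc2ccccc2N1S(=O)(=O)c1ccc(N)cc1` gives 35300 nM, and the step of a 2.0-fold lower number from compound 1 to compound 2 (0.30 log units; within the scatter) came with amino in place of hydrogen on an aromatic carbon — that is, amino in place of hydrogen on an aromatic carbon. Compound 3 `CC1CCc2ccccc2N1S(=O)(=O)c1cccc([N+](=O)[O-])c1` differs from compound 1 by nitro in place of hydrogen on an aromatic carbon. Among the measured compounds shown here, the one step known for adding a group to this ring stayed within the scatter, so for compound 3 no step beyond the scatter is expected, a 1.2-fold lower number from compound 1 to compound 3 (0.07 log units; within the scatter). Compound 3 is therefore estimated at 60000 nM, between 25000 nM and 140000 nM.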

Compound 3, half-maximal inhibitory concentration: 187000 nM
Estimate against measurement, compound 3: 3.1-fold (0.49 log units) below; the whole stated range lies below it.
By their numbers in this assay, from the lowest: compounds 2 and 1 (each within the scatter of the next); then compound 3.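

Nitro in place of hydrogen, on an aromatic carbon meta to a large group, gives the first step on this ring that lies beyond the scatter: a 2.7-fold higher number from compound 1 to compound 3 (0.43 log units; beyond the scatter) in this assay. A single added group on this ring can therefore shift the number, and this shift is toward weaker inhibition. No measurement here accounts for the step.

Among the compounds shown here, with only one nitro compound, the effect of moving nitro elsewhere on the ring stays open. Also open, on these data alone, is whether a carboxylic acid or a methoxy group on the same carbon would raise the number too.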